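This account rests on a few compounds, and the source may have more. Where it says the series, first, only, none or still open, it means among the compounds named here.

Of the compounds shown here, two from this series have been tested so far. Compound 1 `C=C1CC[C@@H]2[C@](C)(CO[Si](C(C)C)(C(C)C)C(C)C)[C@H](OC(C)=O)CC[C@@]2(C)[C@@H]1C/C=C1/C(=O)OC[C@H]1OC(C)=O` gives 18.8 uM in a functional assay on Lu1 cells (Homo sapiens) for cytotoxicity, read by sulforhodamine B assay; a higher number here means that more compound is needed for the effect, a lower number that less compound is needed. Compound 2 `C=C1CC[C@@H]2[C@](C)(CO)[C@H](OC(C)=O)CC[C@@]2(C)[C@@H]1C/C=C1/C(=O)OC[C@H]1O` gives 30.6 uM in this assay, the highest of the two numbers, though it sits within the scatter of compound 1. Compound 3 `C=C1CC[C@@H]2[C@](C)(CO)[C@H](OC(C)=O)CC[C@@]2(C)[C@@H]1C/C=C1/C(=O)OC[C@H]1OC(C)=O` differs from compound 2 by acetyl in place of hydrogen on an oxygen on a saturated carbon. Among the measured compounds shown here, no measured pair shows this change alone, so the expected step from compound 2 to compound 3 in this assay is estimated as small, a 1.2-fold lower number from compound 2 to compound 3 (0.09 log units; within the scatter), with no clear direction beyond the scatter. Compound 3 is therefore expected to give about 25 uM, in a range from 12 uM to 50 uM.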

Compound 3, concentration for half-maximal effect: 8.75 uM
For compound 3 the middle estimate is 2.9-fold (0.46 log units) above the measured one; measured number outside the range, below it.
By their numbers in this assay, from the lowest: compound 3; then compounds 1 and 2 (each within the scatter of the next).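

Acetyl in place of hydrogen on an oxygen on a saturated carbon gives a 3.5-fold lower number from compound 2 to compound 3 (0.54 log units; beyond the scatter) in this assay, the first step in this series beyond the scatter, so the number responds to hydroxy to acetoxy at this position. Removing the silicon-bearing group of 10 heavy atoms from the other oxygen, leaving a hydrogen atom, gives a 2.1-fold lower number from compound 1 to compound 3 (0.33 log units; beyond the scatter), also beyond the scatter. Nothing at hand accounts for either step. The compounds shown leave open whether a longer chain ester, an amine or a carboxylic acid on the first oxygen would shift the number further.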